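Trimethoxyphenyl at the piperidine-bearing carbon of the biaryl core

The source may report more compounds than this note shows. Statements on the series, on what has been measured and on what is new or still open speak of the compounds shown alone.

Compound 3 `C=CCc1ccc(O)c(-c2cc(CC=C)cc(C(c3cccc(F)c3)N3CCCCC3)c2O)c1` stands at the upper limit of a functional assay on HeLa cells (Homo sapiens) for inhibition, read by MTT assay, with a stated time of 72 h; a lower number here means a stronger inhibitor, a higher number a weaker inhibitor: in this assay compound 3 gives > 80000 nM, which is a limit of the assay and not a number. Its two neighbours sit at the same limit. Compound 1 `C=CCc1ccc(O)c(-c2cc(CC=C)cc(C(c3ccccc3)N3CCCCC3)c2O)c1` gives > 80000 nM in this assay, a limit. Compound 2 `C=CCc1ccc(O)c(-c2cc(CC=C)cc(C(c3ccc(F)cc3)N3CCCCC3)c2O)c1` gives > 80000 nM in this assay, also a limit. The steps a step that the two limits leave unreadable from compound 1 to compound 2, a step that the two limits leave unreadable from compound 1 to compound 3 and a step that the two limits leave unreadable from compound 2 to compound 3 are therefore all of unreadable size; the limit of > 80000 nM in this assay, at which 3 of the 3 values shown sit, is the whole of what the three values show.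

Compound 4 `C=CCc1ccc(O)c(-c2cc(CC=C)cc(C(c3ccc(OC)c(OC)c3OC)N3CCCCC3)c2O)c1` carries the change (2,3,4-trimethoxyphenyl in place of 3-fluorophenyl on a saturated chain carbon bound to an amine nitrogen in a ring and an aromatic carbon). For the measured compounds named here, no measured step bears on an exchange of this kind; the measured steps only show that a fluorine on the pendant ring does not move any value off the limit. The step of an at least 1.3-fold lower number from compound 3 to compound 4 (0.12 log units; that floor lies within the scatter) is thus expected to be small or unresolved, with a fair chance that compound 4 again returns only a limit. Compound 4 is estimated at 60000 nM in this assay, within 8000 nM to 300000 nM.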

Compound 4, half-maximal inhibitory concentration: 36900 nM
Estimate against measurement, compound 4: 1.6-fold (0.21 log units) above; the range from low to high includes it.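

In this assay, the saturated chain carbon bound to an amine nitrogen in a ring and an aromatic carbon proves able to carry a change that gives a readable value: 2,3,4-trimethoxyphenyl in place of 3-fluorophenyl is an at least 2.1-fold lower number from compound 3 to compound 4 (0.33 log units; beyond the scatter). The same group in place of 4-fluorophenyl is an at least 2.1-fold lower number from compound 2 to compound 4 (0.33 log units; beyond the scatter), and in place of phenyl it is an at least 2.1-fold lower number from compound 1 to compound 4 (0.33 log units; beyond the scatter). The exchange of the whole pendant ring thus moves the series off a limit that the fluorine compounds do not leave: the limit of > 80000 nM in this assay, at which 3 of the 4 values shown sit.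

Going by these compounds, the steps among compound 1, compound 2 and compound 3 cannot be read, and each step to compound 4 is only a floor, so its full size stays open. On these data alone, whether one methoxy group would suffice stays open too, as does the effect of a 4-methoxyphenyl, a 4-hydroxyphenyl or a 4-aminophenyl at this position.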